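A few compounds are considered here, and "the series" means these few. Any claim that something is new, unique, unknown or untested is made for them only; others in the source may bear on it.

Compound 1, `CS(=O)(=O)c1ccc(F)c(C#Cc2cc(Cl)ccc2OCC(=O)O)c1`: 24%
Compound 2, `CC(C)c1ccc(S(C)(=O)=O)cc1C#Cc1cc(C#N)ccc1OCC(=O)O`: 26%

Both numbers come from an in vivo ADME assay on the whole organism (strain BALB/c) for pharmacokinetics, with Mus musculus as the target, read by LC-MS, at a dose of 5 mg/kg by the oral route; a higher number here means that a larger share of the oral dose reaches the circulation, a lower number that a smaller share of the oral dose reaches the circulation. Compound 1 and compound 2 differ in several places at once, and their two values lie within the usual scatter of each other, so nothing can be read from that pair about any single change. Compound 3, `CCCS(=O)(=O)c1ccc(F)c(C#Cc2cc(Cl)ccc2OCC(=O)O)c1`, has not yet been measured. It is built from compound 1 by one change: ethyl in place of hydrogen on a saturated chain carbon bound to a sulfonyl sulfur. Going by the values given here, no measured pair in this set isolates a change of this kind, so there is no step to lean on. Among the compounds with values here, the only guide is the value of compound 1 in this assay, 24%, together with the observation that compound 2, built differently, lands in the same region. The expected step is therefore a number 1 percentage points higher from compound 1 to compound 3 (within the scatter), none beyond the scatter, and the wide range reflects how little the two measured compounds constrain it. Compound 3 is estimated to give 25% in this assay, within a range of 10% to 45%.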

Compound 3, oral bioavailability: 63%
Compound 3: the middle estimate sits 38 percentage points below what was measured; measured number above the stated range.
By their numbers in this assay, from the lowest: compounds 1 and 2 (each within the scatter of the next); then compound 3.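

Going by these compounds alone, replacing methylsulfonyl with propylsulfonyl brings a number 39 percentage points higher from compound 1 to compound 3 (beyond the scatter) in this assay and this is the first change in the set that can be read on its own. It shows that the saturated chain carbon bound to a sulfonyl sulfur is a place where a small addition can move this read-out far beyond the scatter, something the comparison of compound 1 with compound 2 could not show because those two differ in several places at once. The ethyl that enters has only 2 carbon atoms, no ring, no hydrogen-bond donors or acceptors and no net charge, and no measurement here says what lies behind the step.

With only the methyl and propyl forms of this chain shown, it remains open whether ethylsulfonyl would give part of the step, and whether a butyl chain or a cyclopropyl ring on the sulfonyl would extend the gain or lose it. From the compounds shown here alone, it also remains open whether the same change would pay off on compound 2, which carries methylsulfonyl too but differs elsewhere from compound 1.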